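Swapping a hydroxy for a methyl on compound 2

The compounds below may be only part of what the source reports. "The series", "measured", "known", "first", "only" and "open" are said of these compounds alone.

Compound 1 `COc1ccc2c(c1)CC[C@H](O)/C2=C/c1cc(OC)c(OC)c(OC)c1` gives 1 nM (measured)
Compound 2 `COc1ccc(/C=C2\c3cc(OC)c(OC)c(OC)c3CC[C@@H]2O)cc1O` gives 1060 nM (measured)

In a functional assay on SK-OV-3 cells (Homo sapiens) for inhibition, read by MTT assay (a lower number here means a stronger inhibitor, a higher number a weaker inhibitor), compound 2 stands at 1060 nM as the higher of the two numbers, and its gap to compound 1 lies well beyond the usual scatter. Compound 3 `COc1ccc(/C=C2\c3cc(OC)c(OC)c(OC)c3CC[C@@H]2O)cc1C` is not yet measured. It carries methyl in place of hydroxy on an aromatic carbon, ortho to a methoxy group, so 3-hydroxy-4-methoxyphenyl becomes 4-methoxy-3-methylphenyl. Within the data shown here, no measured pair shows this change, and compound 1 differs from compound 2 in more than one place, so the expectation is uncertain. The expected step (a 1.1-fold lower number from compound 2 to compound 3 (0.03 log units; within the scatter)) stays within the scatter, with no firm direction. For compound 3 the estimated value is 1000 nM (expected range 250 nM to 4000 nM).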

Compound 3, half-maximal inhibitory concentration: 730 nM
Beside the measured number, compound 3's estimate is 1.4-fold (0.14 log units) above it; the measured number falls inside the stated range.
By their numbers in this assay, from the lowest: compound 1; then compounds 3 and 2 (each within the scatter of the next).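

In this assay, among these compounds, putting methyl in place of hydroxy on this aromatic carbon gives the first one-place step in this set (a 1.5-fold lower number from compound 2 to compound 3 (0.16 log units; within the scatter)). At this place, ortho to a methoxy group, a hydroxy group with its hydrogen-bond donor and acceptor can thus be exchanged for a methyl group with neither, and the two numbers cannot be told apart from ordinary repeat-to-repeat variation. No measurement here explains why the two groups read alike.

Compound 1 differs from compound 2 and compound 3 in more than one place, so the compounds shown do not tie its much lower number to any single part of the structure. Also open, on these data alone, is how other groups at this place, such as an amine, a carboxylic acid or a longer chain, would read.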